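The source may report more compounds than this note shows. Statements on the series, on what has been measured and on what is new or still open speak of the compounds shown alone.

Measured so far in an ADME assay on A549 cells (Homo sapiens) for cytotoxicity, read by MTT assay, with a stated time of 48 h; on this read-out lower numbers stand for stronger inhibition and higher numbers for weaker inhibition:
compound 1 `COc1cc(C2CC(c3cc4ccccc4nc3C)=NN2C(C)=O)cc(OC)c1OC`, > 200 ug/mL
compound 2 `CC(=O)N1N=C(c2cc3ccccc3nc2C)CC1c1ccc(C#N)cc1`, > 200 ug/mL
compound 3 `COc1ccc(C2CC(c3cc4ccccc4nc3C)=NN2c2ccccc2)c(OC)c1OC`, 143 ug/mL

Compound 2 stands at the limit of > 200 ug/mL in this assay, at which 2 of the 3 values shown sit, so its value is a limit of the assay and not a number. Compound 1 likewise gives only a limit. Compound 3 gives a number, 143 ug/mL, which is weak inhibition of cell growth. Compound 4 `CC(=O)N1N=C(c2cc3ccccc3nc2C)CC1c1ccc(N(C)C)cc1` is not yet measured; it differs from compound 2 in one place: dimethylamino in place of cyano on an aromatic carbon. Among the measured compounds shown here, with no step between measured compounds to lean on, the step of a number no higher from compound 2 to compound 4 (the limit leaves the size open) is expected to stay within the usual scatter, in no firm direction. Compound 4 is therefore estimated at 200 ug/mL, in the range 100 ug/mL to 400 ug/mL, and most likely reported again only as a limit.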

Compound 4, half-maximal inhibitory concentration: 110 ug/mL
Estimate against measurement, compound 4: 1.8-fold (0.26 log units) above; the measured number falls inside the stated range.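

Among the compounds shown here, replacing 4-cyanophenyl with 4-(dimethylamino)phenyl gives the only step that can be read at this position in this assay: an at least 1.8-fold lower number from compound 2 to compound 4 (0.25 log units; that floor lies within the scatter). That floor alone does not prove a real change, but the swap does turn a limit into a number. Going by these compounds, the true size of the step stays unknown because compound 2 gives only a limit: the limit of > 200 ug/mL in this assay, at which 2 of the 4 values shown sit.

Still open, on these data alone, is whether a primary amine or a carboxylic acid at this place would give a number like that of compound 4 or a limit like that of compound 2.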